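The source may report more compounds than this note shows. Statements on the series, on what has been measured and on what is new or still open speak of the compounds shown alone.

Measured compounds:
- compound 1, `O=C(O)Cc1sc(C(c2ccc(F)cc2)c2ccc(F)cc2)nc1-c1ccccc1`: 240 nM
- compound 2, `O=C(O)Cc1sc(C(c2ccccc2)c2ccccc2)nc1-c1ccc(C(F)(F)F)cc1`: > 100000 nM
- compound 3, `O=C(O)Cc1sc(C(c2ccccc2)c2ccc(Cl)cc2)nc1-c1ccc(Cl)cc1`: 75 nM

Of the compounds shown here, three sharing one core have been tested in an in vitro functional assay on HEK285-7 cells for antagonist activity at prostaglandin D2 receptor 2 (Homo sapiens), read by BRET and beta-arrestin recruitment; on this read-out higher numbers stand for weaker inhibition and lower numbers for stronger inhibition. Compound 1 gives 240 nM, which is the higher of the two numbers recorded, with compound 3 at 75 nM sitting beyond the usual scatter of this assay. For compound 2 the result of this assay is only a limit, > 100000 nM, and not a measured number; (the limit of > 100000 nM in this assay, at which 1 of the 3 values shown sits), so no inhibition could be resolved there.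

The next compound to be measured in this assay is compound 4, `Cc1cc(-c2nc(C(c3ccc(F)cc3)c3ccc(F)cc3)sc2CC(=O)O)ccn1`. It differs from compound 1 in a single place: 2-methylpyridin-4-yl in place of phenyl on an aromatic carbon. Among the compounds with values here, nothing among the measured compounds tests this kind of change, since all three carry a carbon-only ring in that position, so no step for it is on record. A modest change in this assay is expected from compound 1 to compound 4, a 1.7-fold higher number from compound 1 to compound 4 (0.22 log units; within the scatter), with weaker inhibition somewhat more likely than stronger. Compound 4 is therefore estimated at 400 nM in this assay, within a range from 100 nM to 2000 nM.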

Compound 4, half-maximal inhibitory concentration: 53 nM
The estimate for compound 4 lay 7.5-fold (0.88 log units) above the measured number; the measured number lies below the stated range.
By their numbers in this assay, from the lowest: compounds 4 and 3 (each within the scatter of the next); then compound 1. At a limit, above all of these: compound 2.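

In this assay, putting 2-methylpyridin-4-yl in place of phenyl gives a 4.5-fold lower number from compound 1 to compound 4 (0.66 log units; beyond the scatter). Within the data shown here, this is the first sign that the aromatic carbon next to the ring nitrogen tolerates more than a ring of carbon only: a six-membered aromatic ring with a hetero atom, one hydrogen-bond acceptor and a methyl group is accepted there, and inhibition grows stronger rather than being lost. The data shown offer no measured property that accounts for this step.

As far as these compounds go, the change brings in a ring nitrogen and a methyl group at once, so the share of each in the gain remains open. A plain pyridin-4-yl group or a 3-methylphenyl group on the same carbon would separate the two, and a 2-aminopyridin-4-yl group would show whether another substituent can take the place of the methyl.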